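The compounds below may be only part of what the source reports. "The series", "measured", "known", "first", "only" and "open" are said of these compounds alone.

In a functional assay on HL-60 cells (Homo sapiens) for antiproliferative activity, with a stated time of 72 h (a lower number here means a stronger inhibitor, a higher number a weaker inhibitor), compound 1 (`OC[C@H]1O[C@@H](n2cnc3c(NCc4ccc(Cl)cc4)ncnc32)[C@H](O)[C@@H]1O`) gives 1700 nM and compound 2 (`COc1ccccc1CNc1ncnc2c1ncn2[C@@H]1O[C@H](CO)[C@@H](O)[C@H]1O`) gives 2300 nM while compound 3 (`OC[C@H]1O[C@@H](n2cnc3c(NCc4ccc(Cl)cc4Cl)ncnc32)[C@H](O)[C@@H]1O`) gives 96300 nM as the highest number and the weakest result of the three. The next structure is compound 4 (`COc1cc(CNc2ncnc3c2ncn3[C@@H]2O[C@H](CO)[C@@H](O)[C@H]2O)cc(OC)c1`) and its change is 3,5-dimethoxyphenyl in place of 2,4-dichlorophenyl on a saturated chain carbon bound to a nitrogen on an aromatic ring on the shared core. Two large measured steps bear on this change: a 57-fold higher number from compound 1 to compound 3 (1.75 log units; beyond the scatter) and a 42-fold higher number from compound 2 to compound 3 (1.62 log units; beyond the scatter) both lie beyond the scatter, whereas a 1.4-fold higher number from compound 1 to compound 2 (0.13 log units; within the scatter) stays within it. Among the measured compounds shown here, only compound 3 carries 2,4-dichlorophenyl, and no measured compound carries 3,5-dimethoxyphenyl. A large step towards a lower number is therefore expected, with a 16-fold lower number from compound 3 to compound 4 (1.21 log units; beyond the scatter) as the estimate here. Compound 4 is estimated at 6000 nM with an expected range from 1500 nM to 40000 nM for this measurement.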

Compound 4, half-maximal inhibitory concentration: 20200 nM
Compound 4: the middle estimate sits 3.4-fold (0.53 log units) below what was measured, within the range that was stated.
By their numbers in this assay, from the lowest: compounds 1 and 2 (each within the scatter of the next); then compound 4; then compound 3.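

In this assay the 3,5-dimethoxyphenyl group gives back only part of what the 2,4-dichlorophenyl group loses, with a 4.8-fold lower number from compound 3 to compound 4 (0.68 log units; beyond the scatter) but still an 8.8-fold higher number from compound 2 to compound 4 (0.94 log units; beyond the scatter) and a 12-fold higher number from compound 1 to compound 4 (1.07 log units; beyond the scatter) as well. Among these four compounds, the two with a doubly substituted phenyl, compounds 3 and 4, both give higher numbers than compounds 1 and 2, which have a singly substituted one. No measurement here explains this. A 3,5-dichlorophenyl group would help separate the effect of chlorine versus methoxy from that of their placement. As far as these compounds go, whether an amine or a longer chain is tolerated at this position remains open.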